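The source may hold more compounds than are shown below. What is called first, only, known or untested is meant among the compounds shown, and "the series" means these compounds.

Measured so far:
- compound 1 `Cc1cccc2c1nc(COc1ccc(Cl)cc1)n2CCCC1CCN(CCC(C)C)CC1` — in an assay on AV12 cells for binding affinity to Neuropeptide Y receptor type 1 (Homo sapiens) (on this read-out higher numbers stand for weaker inhibition and lower numbers for stronger inhibition), compound 1 gives 11 nM
- compound 2 `Cc1cccc2c1nc(COc1ccc(Cl)cc1)n2CCCC1CCN(Cc2ccccc2)CC1` — in this assay compound 2 gives 109 nM

Among the compounds with values here, compound 2 gives the higher of the two numbers; its only neighbour is compound 1, and the step of a 9.9-fold higher number from compound 1 to compound 2 (1.00 log units; beyond the scatter) lies beyond the scatter. Compound 3 `Cc1cccc2c1nc(COc1ccc(Cl)cc1)n2CCCC1CCN(CCCc2ccccc2)CC1` differs from compound 2 by phenethyl in place of phenyl on a saturated chain carbon bound to an amine nitrogen in a ring; the same difference, cut one bond further out, reads benzyl to 3-phenylpropyl. Within the data shown here, the only measured step that bears on this place is the one from compound 1 to compound 2, where exchanging isobutyl for phenyl weakened binding; the change to compound 3 moves the ring outward on a longer chain, closer in reach to the isobutyl of compound 1. Some recovery toward compound 1 is therefore expected, but not the full step back. The estimate for compound 3 in this assay is 35 nM, with a range from 9 nM to 130 nM, meaning an expected step of a 3.1-fold lower number from compound 2 to compound 3 (0.49 log units; beyond the scatter).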

Compound 3, inhibition constant: 57 nM
Compound 3: the middle estimate sits 1.6-fold (0.21 log units) below what was measured; measured number inside the range.
By their numbers in this assay, from the lowest: compound 1; then compounds 3 and 2 (each within the scatter of the next).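

In this assay, phenethyl in place of phenyl on the saturated chain carbon bound to the ring amine nitrogen gives a 1.9-fold lower number from compound 2 to compound 3 (0.28 log units; within the scatter), so the longer chain cannot be told apart from the shorter one here. Compound 3 still stands apart from the isobutyl compound, with a 5.2-fold higher number from compound 1 to compound 3 (0.71 log units; beyond the scatter), so in these compounds, moving the phenyl ring further out along the chain does not bring the number back to that of compound 1. No measurement at hand accounts for either result.

On these data alone, whether a cyclohexyl group or a longer straight alkyl chain in this place would match compound 1 remains open. As far as these compounds go, it is also open whether a methoxy group or an amine on the phenyl ring of compound 3 would shift its number beyond the scatter.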